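Pyrrolidin-1-yl to piperidin-1-yl on the shared core

The compounds below may be only part of what the source reports. "The series", "measured", "known", "first", "only" and "open" are said of these compounds alone.

Compound 1 `CCc1ccc(NC2=CC(=O)c3c(nc4n3[C@H]3OC[C@@H](O)[C@H]3OC4)C2=O)cc1` gives 6510 nM
Compound 2 `O=C1C(N2CCCC2)=CC(=O)c2c1nc1n2[C@H]2OC[C@@H](O)[C@H]2OC1` gives > 16000 nM

In a functional assay on HeLa cells (Homo sapiens) for inhibition, read by sulforhodamine B assay (a lower number here means a stronger inhibitor, a higher number a weaker inhibitor), compound 2 stands at the limit of > 16000 nM in this assay, at which 1 of the 2 values shown sits, which is a limit and not a number. Compound 3 `O=C1C(N2CCCCC2)=CC(=O)c2c1nc1n2[C@H]2OC[C@@H](O)[C@H]2OC1` differs from it by piperidin-1-yl in place of pyrrolidin-1-yl on a double-bonded ring carbon, on a double-bonded ring carbon. Among the compounds with values here, the only measured step, an at least 2.4-fold higher number from compound 1 to compound 2 (0.39 log units; beyond the scatter), suggests that compound 3, like compound 2, stays a weak inhibitor in this assay, and no step beyond the scatter is expected. The expected step is a step that the limit leaves unreadable from compound 2 to compound 3 as estimated here. For compound 3 the estimated value is 20000 nM, with an expected range from 8000 nM to 50000 nM.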

Compound 3, half-maximal inhibitory concentration: > 16000 nM
Compound 3 was reported as a limit; the forecaster's own chance of this, stated with the estimate: 65%; the middle value is on the limit's open side.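

The change away from (4-ethylphenyl)amino at this double-bonded ring carbon now reads alike for two cyclic amines, with piperidin-1-yl giving an at least 2.4-fold higher number from compound 1 to compound 3 (0.39 log units; beyond the scatter). The step between pyrrolidin-1-yl and piperidin-1-yl cannot be read, so these data say nothing about the ring size of the amine. In this assay compound 3 is a limit and not a number: the limit of > 16000 nM in this assay, at which 2 of the 3 values shown sit.

Open, on these data alone, is whether a secondary arylamine other than (4-ethylphenyl)amino, such as benzylamino or (4-methoxyphenyl)amino, would give a measurable value at this carbon. Morpholin-4-yl or a simple open-chain amine such as dimethylamino also remains open.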